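Hydrazone aryl swaps on the shared core

A few compounds are considered here, and "the series" means these few. Any claim that something is new, unique, unknown or untested is made for them only; others in the source may bear on it.

The series shares one core and varies the aryl group on a carbon with a double bond to nitrogen. Compound 1 `NS(=O)(=O)c1ccc(Nc2nc(N/N=C/c3ccc(C(F)(F)F)cc3)nc(Nc3ccccc3)n2)cc1` gives 3050 nM in a functional assay on CAKI-1 cells (Homo sapiens) for inhibition, read by sulforhodamine B assay, with a stated time of 48 h; a higher number here means a weaker inhibitor of growth, a lower number a stronger inhibitor of growth. Compound 2 `Cc1nn(-c2ccccc2)cc1/C=N/Nc1nc(Nc2ccccc2)nc(Nc2ccc(S(N)(=O)=O)cc2)n1` gives 2010 nM in this assay; this is the lower of the two numbers, but the gap to compound 1 lies within the scatter, so the two stand level on present data. Going by the values given here, the only measured step, a 1.5-fold lower number from compound 1 to compound 2 (0.18 log units; within the scatter), is itself an aryl swap at the same place and moved nothing beyond the scatter.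

Compound 3 `NS(=O)(=O)c1ccc(Nc2nc(N/N=C/c3ccccn3)nc(Nc3ccccc3)n2)cc1` carries the change (pyridin-2-yl in place of 3-methyl-1-phenyl-1H-pyrazol-4-yl on a carbon with a double bond to nitrogen). Among the compounds with values here, the one step that bears on it is that from compound 1 to compound 2, an exchange of a six-membered aromatic ring of carbon only for a 3-methyl-1-phenyl-1H-pyrazol-4-yl at the same carbon, which stayed within the scatter; no step involving pyridin-2-yl has been measured. The expected step of a 1.2-fold higher number from compound 2 to compound 3 (0.09 log units; within the scatter) is therefore none beyond the scatter. Compound 3 is estimated at 2500 nM, with a range of 1000 nM to 6500 nM.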

Compound 3, concentration for 50% growth inhibition: 610 nM
For compound 3 the middle estimate is 4.1-fold (0.61 log units) above the measured one; measured number below the stated range.
By their numbers in this assay, from the lowest: compound 3; then compounds 2 and 1 (each within the scatter of the next).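

In this assay this place, on a carbon with a double bond to nitrogen, proves sensitive to the group it carries: pyridin-2-yl gives a 3.3-fold lower number from compound 2 to compound 3 (0.52 log units; beyond the scatter) and also a 5.0-fold lower number from compound 1 to compound 3 (0.70 log units; beyond the scatter) while the swap between the two earlier groups stayed within the scatter. Both new steps are modest, but they set compound 3 apart from compound 1 and compound 2, so the level standing of those two does not hold for every aryl group at this carbon. The entering group differs from 3-methyl-1-phenyl-1H-pyrazol-4-yl in two ways at once, with one six-membered aromatic ring holding a hetero atom in place of a two-ring group, and no supporting measurement is available to explain the lower number.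

The compounds shown leave open whether the ring nitrogen or the reduction to a single ring accounts for the step, a question that an unsubstituted phenyl, pyridin-3-yl or pyridin-4-yl at the same carbon would address. They also leave open whether pyridin-2-yl tolerates further substitution, for instance with an amine or a methoxy group.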